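Capping the free amine of compound 2 with an acyl ring

The compounds below may be only part of what the source reports. "The series", "measured", "known", "first", "only" and "open" are said of these compounds alone.

Measured compounds in an assay on IMR-32 cells for inhibition of Voltage-dependent N-type calcium channel subunit alpha-1B (Homo sapiens); on this read-out higher numbers stand for weaker inhibition and lower numbers for stronger inhibition:
compound 1 `COc1ccc(COC(=O)[C@H](CSCC2CCCCC2)NC(=O)OC(C)(C)C)cc1` gives 610 nM
compound 2 `COc1ccc(COC(=O)[C@@H](N)CSCC2CCCCC2)cc1` gives 5800 nM

Compound 2 stands with the highest number of the two, and its nearest neighbour is compound 1. Among the compounds with values here, the only step recorded between them, a 9.5-fold higher number from compound 1 to compound 2 (0.98 log units; beyond the scatter), is the removal of the tert-butoxycarbonyl cap from the amine nitrogen, and it moved the read-out beyond the scatter towards weaker inhibition.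

Compound 3 `COc1ccc(COC(=O)[C@H](CSCC2CCCCC2)NC(=O)[C@@H]2CSCN2)cc1` is not yet measured. It differs from compound 2 by (1,3-thiazolidin-4-yl)carbonyl in place of hydrogen on an amine nitrogen. Within the data shown here, this change puts a carbonyl-bearing group back onto the same nitrogen that carried the tert-butoxycarbonyl in compound 1, so the step from compound 1 to compound 2 is the only measured step that bears on it, and it was modest. Among the measured compounds shown here, an amide is not a carbamate, so only part of that step is expected to be regained; a step toward lower numbers, beyond the scatter but smaller than the one from compound 1 to compound 2, is expected, namely a 3.9-fold lower number from compound 2 to compound 3 (0.59 log units; beyond the scatter). For compound 3 the estimate in this assay is therefore 1500 nM, with a range from 400 nM to 5000 nM.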

Compound 3, half-maximal inhibitory concentration: 2700 nM
Estimate against measurement, compound 3: 1.8-fold (0.26 log units) below, within the range that was stated.
By their numbers in this assay, from the lowest: compound 1; then compound 3; then compound 2.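

In this assay, (1,3-thiazolidin-4-yl)carbonyl on the amine nitrogen gives a 2.1-fold lower number from compound 2 to compound 3 (0.33 log units; beyond the scatter), so a return towards stronger inhibition at this nitrogen is not confined to the tert-butoxycarbonyl cap and is also seen with an amide. The two caps are not interchangeable, however: exchanging tert-butoxy for 1,3-thiazolidin-4-yl on the carbonyl carbon gives a 4.4-fold higher number from compound 1 to compound 3 (0.65 log units; beyond the scatter), so the group carried by this carbonyl carbon affects the read-out, with the amide recovering only part of the loss seen on removing the carbamate cap. No measurement at hand accounts for either step.

The compounds shown leave open whether the gap between the two capped compounds follows from the change of carbamate to amide or from the thiazolidine ring itself, and a 2,2-dimethylpropanoyl amide, which would carry a tert-butyl group on the carbonyl carbon, would help separate the two. Also open, from the compounds shown here alone, is the part played by the ring nitrogen and sulfur of the cap, which a cyclopentanecarbonyl amide would bear on.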